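A Halogen Swap at the Far End of the Chain

The compounds below may be only part of what the source reports. "The series", "measured", "known", "first", "only" and "open" are said of these compounds alone.

Of the compounds shown here, two sharing one core have been tested in a functional assay on A549 cells (Homo sapiens) for antiproliferative activity, read by MTT assay, with a stated time of 48 h; a higher number here means a weaker inhibitor, a lower number a stronger inhibitor. Compound 1 `O=C(/C=C/c1ccccc1)Nc1ccc2ncnc(Nc3cccc(Br)c3)c2c1` gives 3.96 ug/mL in this assay. Compound 2 `O=C(/C=C/c1ccccc1Cl)Nc1ccc2ncnc(Nc3cccc(Br)c3)c2c1`, which carries a chlorine on the outer ring, gives 6.63 ug/mL in this assay. Among the measured compounds shown here, the only step measured so far is a 1.7-fold higher number from compound 1 to compound 2 (0.22 log units; within the scatter), so the two numbers are not distinguishable. Compound 2 has the highest of the two numbers, with compound 1 as its nearest neighbour at a distance that falls inside the scatter.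

Compound 3 `O=C(/C=C/c1ccc(Br)cc1)Nc1ccc2ncnc(Nc3cccc(Br)c3)c2c1` is not yet measured. It differs from compound 2 by 4-bromophenyl in place of 2-chlorophenyl on a double-bonded chain carbon bound to a double-bonded chain carbon. For the measured compounds named here, the one measured step bearing on this region, the addition of chlorine to that same ring, moved the number by only a 1.7-fold higher number from compound 1 to compound 2 (0.22 log units; within the scatter), and there is no measured step that shows a halogen being moved around that ring or exchanged for another. On that basis the expected step from compound 2 to compound 3 is a 1.3-fold lower number from compound 2 to compound 3 (0.12 log units; within the scatter), nothing beyond the scatter. Compound 3 is therefore estimated at 5 ug/mL in this assay, within a range from 2.3 ug/mL to 11 ug/mL.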

Compound 3, half-maximal inhibitory concentration: 15.3 ug/mL
Compound 3: middle estimate off by 3.1-fold (0.49 log units), on the low side; measured number above the stated range.
By their numbers in this assay, from the lowest: compounds 1 and 2 (each within the scatter of the next); then compound 3.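

In this assay, the outer ring at the far end of the chain proves sensitive to what it carries: 4-bromophenyl in place of 2-chlorophenyl gives a 2.3-fold higher number from compound 2 to compound 3 (0.36 log units; beyond the scatter), and bromo in place of hydrogen gives a 3.9-fold higher number from compound 1 to compound 3 (0.59 log units; beyond the scatter), both modest steps toward a weaker inhibitor. Among the compounds shown here, until now the only change on this ring, chloro in place of hydrogen, stayed within the scatter, so these are the first steps showing that a halogen on this ring can make a real difference to the number, and that not every halogen placement behaves alike. Nothing measured here accounts for the shift.

The step to compound 3 changes both the halogen and where it stands on the ring, so the compounds shown cannot say which of the two matters, or whether both do. They also leave open how this ring would respond to a group that is not a halogen, such as a methoxy group or an amine, in place of the chlorine or bromine.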